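This account rests on a few compounds, and the source may have more. Where it says the series, first, only, none or still open, it means among the compounds named here.

Measured in an ADME assay on BJ cells (Homo sapiens) for cytotoxicity, with a stated time of 72 h; on this read-out lower numbers stand for an effect already at smaller amounts and higher numbers for an effect only at larger amounts of compound:
- compound 1 `COc1ccc(NC(=O)Nc2cc(C)nc3ccccc23)cc1Cl` gives 23000 nM
- compound 2 `COC(=O)c1cccc(NC(=O)Nc2cc(C)nc3ccccc23)c1` gives 21000 nM
- compound 3 `COc1cccc(NC(=O)Nc2cc(C)nc3ccccc23)c1` gives 27000 nM

Compound 3 at 27000 nM lies within the scatter of both other compounds, so the three values cannot be ranked. Compound 4 `Cc1cc(NC(=O)Nc2cccc(Cl)c2)c2ccccc2n1` differs from compound 3 by chloro in place of methoxy on an aromatic carbon with chloro in place of methoxy on an aromatic carbon, meta to a large group. For the measured compounds named here, one measured step bears on this exchange: a 1.3-fold higher number from compound 2 to compound 3 (0.11 log units; within the scatter) also replaced a group on an aromatic carbon and stayed within the scatter. Compound 1, which carries a chloro as well as a methoxy, gives 23000 nM and also sits within that scatter. No step beyond the scatter is therefore expected in this assay, and the estimated change is a 1.1-fold lower number from compound 3 to compound 4 (0.05 log units; within the scatter) only. For compound 4 the expected value is 24000 nM with an estimated range of 12000 nM to 45000 nM in this read-out.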

Compound 4, half-maximal effective concentration: > 25000 nM
Compound 4 was reported as a limit; the forecaster's own chance of this, stated with the estimate: 15%; at least 1.0-fold (0.01 log units) between middle value and limit.
By their numbers in this assay, from the lowest: compounds 2, 1 and 3 (each within the scatter of the next).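

In this assay compound 4 gives > 25000 nM as a limit of the assay and not a number. Its steps from the other two compounds give only floors (an at least 1.1-fold higher number from compound 2 to compound 4 (0.07 log units; that floor lies within the scatter) and an at least 1.0-fold higher number from compound 1 to compound 4 (0.03 log units; that floor lies within the scatter)), so neither shows a step beyond the scatter. The exchange of methoxy for chloro on this aromatic carbon, meta to a large group, cannot be read, because the value of compound 4 stops at a limit: the limit of > 25000 nM in this assay, at which 1 of the 4 values shown sits.

From the compounds shown here alone, how far past that limit compound 4 lies stays open. So does how an amine or a carboxylic acid at this place would read in this assay on the same core.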